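The source may hold more compounds than are shown below. What is called first, only, known or untested is meant among the compounds shown, and "the series" means these compounds.

Measured so far in a functional assay on MGC-803 cells (Homo sapiens) for antiproliferative activity, read by CCK-8 assay, with a stated time of 72 h, tested at 8 uM; a lower number here means a weaker effect, a higher number a stronger effect of the compound at the concentration tested:
compound 1 `CN(Cc1cccnc1)C(=S)SCc1ccc(C(=O)Nc2ccccc2N)cc1` gives 85.5%
compound 2 `Nc1ccccc1NC(=O)c1ccc(CSC(=S)N2CCN(c3cnccn3)CC2)cc1` gives 80.5%
compound 3 `N#Cc1ccc(N2CCN(C(=S)SCc3ccc(C(=O)Nc4ccccc4N)cc3)CC2)cc1` gives 37.6%

Compound 1 stands highest of the three numbers; compound 2 lies within the scatter of it, while compound 3 lies far lower. Among the compounds with values here, the single measured step, a number 42.9 percentage points lower from compound 2 to compound 3 (beyond the scatter), is large and downward and is the only step that bears, loosely, on the change now considered.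

Compound 4 `Nc1ccccc1NC(=O)c1ccc(CSC(=S)N2CCc3ccccc32)cc1` is not yet measured. It differs from compound 1 by 2,3-dihydro-1H-indol-1-yl in place of methyl((pyridin-3-yl)methyl)amino on a thiocarbonyl carbon. Within the data shown here, no measured pair changes the group on the thiocarbonyl carbon itself, so the direction rests only on the step from compound 2 to compound 3, which points downward. A downward step of moderate size, a number 25.5 percentage points lower from compound 1 to compound 4 (beyond the scatter), is therefore expected in this assay. For compound 4 the estimate is 60%, with a range from 30% to 85%.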

Compound 4, a percentage reported as inhibition, at one concentration (the size of the read-out at that concentration, not a potency): 87%
The estimate for compound 4 lay 27 percentage points below the measured number; measured number above the stated range.
By their numbers in this assay, from the lowest: compound 3; then compounds 2, 1 and 4 (each within the scatter of the next).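

In this assay, 2,3-dihydro-1H-indol-1-yl replaces methyl((pyridin-3-yl)methyl)amino on the thiocarbonyl carbon with a number 1.5 percentage points higher from compound 1 to compound 4 (within the scatter), so this position accepts both groups without a change beyond the scatter. The entering group has no hydrogen-bond acceptor and its six-membered aromatic ring is of carbon only, so neither the pyridine ring nor an acceptor in this group is required for the read-out at the concentration tested. No data on hand explain this result.

Open, going by these compounds, is how a morpholine ring or a simple longer alkyl chain on the thiocarbonyl carbon would read in this assay. A reading at one concentration also leaves the relative potency of the two compounds open.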